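Cyclopropyl for 4-Fluorophenyl on a Shared Core

The source may hold more compounds than are shown below. What is called first, only, known or untested is meant among the compounds shown, and "the series" means these compounds.

Of the compounds shown here, three built on one shared core have been measured in an assay on isolated protein for binding affinity to sphingosine 1-phosphate receptor 2 (Homo sapiens), read by surface plasmon resonance; on this read-out higher numbers stand for weaker binding and lower numbers for tighter binding. Compound 1 `Cn1ncc2c(-c3ccccc3)cc(NNC(=O)Nc3cc(Cl)nc(Cl)c3)nc21` gives 1020 nM in this assay. Compound 2 `CC(C)c1cc(NNC(=O)Nc2cc(Cl)nc(Cl)c2)nc2c1c(C(F)(F)F)nn2C` gives 1250 nM in this assay. Compound 3 `Cc1nn(C)c2nc(NNC(=O)Nc3cc(Cl)nc(Cl)c3)cc(-c3ccc(F)cc3)c12` gives 980 nM in this assay. Compound 3 shows the lowest of the three numbers, yet its gap to compound 1 and its gap to compound 2 both fall within the scatter of repeated measurements, so the three cannot be told apart on these data.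

Compound 4 `Cc1nn(C)c2nc(NNC(=O)Nc3cc(Cl)nc(Cl)c3)cc(C3CC3)c12` has not yet been measured in this assay. It differs from compound 3 in a single way: cyclopropyl in place of 4-fluorophenyl on an aromatic carbon. Compound 2, which carries an isopropyl group at the same place on its core together with a trifluoromethyl group elsewhere, gives 1250 nM in this assay, a number indistinguishable from that of compound 3. On that basis the exchange of the 4-fluorophenyl group for cyclopropyl is expected to bring no step beyond the scatter, with the estimated step being a 1.3-fold higher number from compound 3 to compound 4 (0.12 log units; within the scatter). Compound 4 is therefore expected to give about 1300 nM in this assay, within a range of 500 nM to 3500 nM.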

Compound 4, dissociation constant: 3650 nM
Compound 4: the middle estimate sits 2.8-fold (0.45 log units) below what was measured, outside the stated range (above it).
By their numbers in this assay, from the lowest: compounds 3, 1 and 2 (each within the scatter of the next); then compound 4.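

In this assay, within the data shown here, the exchange of 4-fluorophenyl for cyclopropyl on this aromatic carbon, opposite the ring nitrogen, gives a 3.7-fold higher number from compound 3 to compound 4 (0.57 log units; beyond the scatter) and thereby provides the first step in this set between two compounds that differ in one place. Among these compounds, it shows that the number at this position does depend on the group it carries, modestly but beyond the scatter, something the earlier compounds could not show, as compound 1, compound 2 and compound 3 lie within the scatter of one another and no two of them differ in one place only. Nothing measured here accounts for the step, so the change of 7 heavy atoms with an aromatic ring to 3 heavy atoms with a non-aromatic ring stands as an observation without an explanation.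

The single exchange alters ring size, ring type and the presence of fluorine together, so the compounds shown do not tell which of these goes with the higher number. From the compounds shown here alone, it also remains open how a cyclohexyl ring, a methoxy group or an amine such as morpholine would read at this place on the core of compound 3.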